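The source may report more compounds than this note shows. Statements on the series, on what has been measured and on what is new or still open speak of the compounds shown alone.

Measured compounds:
compound 1 `O=C1c2ccccc2S(=O)(=O)N1CCCCN1CCN(c2cccc(C(F)(F)F)c2)CC1`: > 5000 nM
compound 2 `COc1ccccc1N1CCN(CCCCCCN2C(=O)c3ccccc3S2(=O)=O)CC1`: "not determined" (no result reported)
compound 3 `O=C1c2ccccc2S(=O)(=O)N1CCN1CCN(c2cccc(C(F)(F)F)c2)CC1`: "not determined" (no result reported)

The three compounds share the same core and differ only in the length of the chain joining it to the piperazine ring and in the aryl group on that ring. In an assay on isolated protein for binding affinity to D(4) dopamine receptor (Homo sapiens) (on this read-out higher numbers stand for weaker inhibition and lower numbers for stronger inhibition), compound 1 gives > 5000 nM, which is a limit of the assay and not a number. Compound 2 gives "not determined" (no result reported) in this assay. Compound 3 likewise gives "not determined" (no result reported) in this assay. Compound 1 thus stands at the limit of > 5000 nM in this assay, at which 1 of the 3 values shown sits, and with no other number available, no measured step between any two of these compounds can be drawn.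

Compound 4 `COc1ccccc1N1CCN(CCCCN2C(=O)c3ccccc3S2(=O)=O)CC1` has not been measured. It differs from compound 1 in a single place: 2-methoxyphenyl in place of 3-(trifluoromethyl)phenyl on an amine nitrogen in a ring. With compound 1 sitting at the limit, only a move toward stronger binding could become visible. The step of an at least 25-fold lower number from compound 1 to compound 4 (1.39 log units; beyond the scatter) is expected to run toward stronger binding, beyond the usual scatter. Compound 4 is expected to give 200 nM in this assay, with a range from 20 nM to 2000 nM.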

Compound 4, inhibition constant: 79 nM
The estimate for compound 4 lay 2.5-fold (0.40 log units) above the measured number, and the stated range covers the measured number.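

Swapping 3-(trifluoromethyl)phenyl for 2-methoxyphenyl on the amine nitrogen in a ring, with the rest of the molecule unchanged, gives an at least 63-fold lower number from compound 1 to compound 4 (1.80 log units; beyond the scatter) in this assay. This shows that the group at this one position can move a compound from no measurable binding in this assay to a clear number. Compound 1 gives > 5000 nM, which is a limit and not a number, so the step has a known minimum but no exact size: the limit of > 5000 nM in this assay, at which 1 of the 4 values shown sits.

The compounds shown do not separate the effect of adding the methoxy group from that of removing the trifluoromethyl group, and no cause for the step can be read from them. On these data alone, it also remains open what a plain phenyl group, or a longer chain in compound 4, would give in this assay.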